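The source may hold more compounds than are shown below. What is called first, only, known or untested is meant among the compounds shown, and "the series" means these compounds.

Compound 1 `C=C(C)CCC[C@]1(C)C2=CCC[C@](C)(CC(=O)c3ccoc3)[C@H]2CC[C@H]1C` stands at the top of the range in a functional assay on A549 cells (Homo sapiens) for antiproliferative activity, read by XTT assay, with a stated time of 72 h (on this read-out higher numbers stand for weaker inhibition and lower numbers for stronger inhibition), and its entry there is only a limit: compound 1 gives > 100000 nM. Compound 2 `CC(C)=CCC[C@]1(C)C2=CCC[C@](C)(CC(=O)c3ccoc3)[C@H]2CC[C@H]1C` gives 91000 nM in this assay, and the measured step, an at least 1.0-fold lower number from compound 1 to compound 2 (0.04 log units; that floor lies within the scatter), concerns the alkene in the chain and leaves the carbonyl untouched. That step therefore says little about a change at the carbonyl.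

Compound 4 `C=C(C)CCC[C@]1(C)C2=CCC[C@](C)(C[C@H](O)c3ccoc3)[C@H]2CC[C@H]1C` differs from compound 1 as follows: (furan-3-yl)(hydroxy)methyl in place of (furan-3-yl)carbonyl on a saturated chain carbon bound to a saturated ring carbon. In short, (furan-3-yl)(hydroxy)methyl replaces (furan-3-yl)carbonyl on a saturated chain carbon bound to a saturated ring carbon. Within the data shown here, no measured step isolates this swap. The nearest hint is compound 3 `C=C(C)CC[C@]1(C)C2=CCC[C@](C)(C[C@H](O)C3=CC(=O)OC3O)[C@H]2CC[C@H]1C`, which also carries a hydroxy group in its side chain but has lost the furan and differs in other places too. In this assay compound 3 gives 4500 nM, so it offers only weak support for a shift towards stronger inhibition.

A modest move towards a lower number is therefore expected, estimated as an at least 2.0-fold lower number from compound 1 to compound 4 (0.30 log units; that floor lies within the scatter), and a reading at the limit remains quite possible. For compound 4 the expected value in this assay is 50000 nM, with an estimated range of 15000 nM to 100000 nM.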

Compound 4, half-maximal inhibitory concentration: 66000 nM
Beside the measured number, compound 4's estimate is 1.3-fold (0.12 log units) below it; measured number inside the range.
By their numbers in this assay, from the lowest: compound 3; then compounds 4 and 2 (each within the scatter of the next). At a limit, above all of these: compound 1.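

With the (furan-3-yl)(hydroxy)methyl in place of the (furan-3-yl)carbonyl on a saturated chain carbon bound to a saturated ring carbon, the series gains its first direct reading of this change in this assay, and the result is an at least 1.5-fold lower number from compound 1 to compound 4 (0.18 log units; that floor lies within the scatter). From the compounds shown here alone, the true size of this step stays unknown because the entry for compound 1 is a limit, so the step gives only a floor: the limit of > 100000 nM in this assay, at which 1 of the 4 values shown sits. The swap adds a hydrogen-bond donor and a defined stereocentre while the furan ring stays in place, and compound 4 gives a definite reading, but these data support no shift beyond the scatter.

Going by these compounds, it remains open whether the opposite configuration at the new stereocentre, a methyl ether or an amine at this carbon would read differently, and whether the hydroxy group would act the same way on the chain of compound 2. The lower number of compound 3 also cannot be assigned to any single change, as that compound differs from the others in more than one place.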